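The source may hold more compounds than are shown below. What is called first, only, known or untested is meant among the compounds shown, and "the series" means these compounds.

Going by the values given here, in a functional assay on the whole organism with Mus musculus as the target, with a stated time of 90 min, at a dose of 25 umol/kg by the oral route (a higher number here means a stronger effect of the compound at the dose given, a lower number a weaker effect), compound 2 `N=C(N)NCCC[C@H](NC(=O)CN(c1nc(Cl)nc2c1ncn2C1CCCCO1)C1CC1)C(=O)OCc1ccccc1` gives 61.6%, the highest of the two numbers measured so far. Compound 1 `C[C@H](NC(=O)CN(c1nc(Cl)nc2c1ncn2C1CCCCO1)C1CC1)C(=O)OCc1ccccc1` gives 32.1%. Among the compounds with values here, the one measured step, a number 29.5 percentage points higher from compound 1 to compound 2 (beyond the scatter), put in the very group that now leaves. Compound 3 `NC(=O)C[C@H](NC(=O)CN(c1nc(Cl)nc2c1ncn2C1CCCCO1)C1CC1)C(=O)OCc1ccccc1` differs from compound 2 by a group of 3 heavy atoms (1 carbon, 1 nitrogen, 1 oxygen; no ring) in place of a group of 6 heavy atoms (3 carbon, 3 nitrogen; no ring), on a saturated chain carbon, two bonds along the chain from an amide-type nitrogen and a carbonyl carbon. Taking that group away is expected to give back part of the gain seen in a number 29.5 percentage points higher from compound 1 to compound 2 (beyond the scatter), while the carbamoyl that enters has no measured counterpart here. Compound 3 is therefore expected to fall by a number 19.6 percentage points lower from compound 2 to compound 3 (beyond the scatter), to an estimated 42%, with a range from 24% to 60%.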

Compound 3, a percentage reported as activity, at one dose (the size of the read-out at that dose, not a potency): 35%
Compound 3: the middle estimate sits 7 percentage points above what was measured, within the range that was stated.
By their numbers in this assay, from the lowest: compounds 1 and 3 (each within the scatter of the next); then compound 2.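

In this assay, carbamoyl in place of the larger group at this position gives a number 26.6 percentage points lower from compound 2 to compound 3 (beyond the scatter), so the gain seen with compound 2 does not carry over to carbamoyl. Against the hydrogen of compound 1, carbamoyl gives a number 2.9 percentage points higher from compound 1 to compound 3 (within the scatter), so a group at this place does not by itself raise the read-out. Nothing measured here explains the difference between these groups.

On these data alone, whether an amine, a carboxylic acid or a longer chain ending in carbamoyl would sit with compound 2 or with compound 3 remains open.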